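A Pyrazolyl Swap in a Series Showing No Inhibition

A few compounds are considered here, and "the series" means these few. Any claim that something is new, unique, unknown or untested is made for them only; others in the source may bear on it.

Three compounds of a shared core were tested in an assay on CHO cells for displacement of a labelled ligand from adenosine receptor A1 (Homo sapiens), read by scintillation counting, tested at 10 uM; a higher number here means more inhibition at the concentration tested (going by the name of the read-out), a lower number less inhibition. Compound 1 `Cc1sc(N)c(C(=O)c2ccc(Cl)cc2)c1-c1ccccc1` gives 1%. Compound 2 `CC(C)(C)Cc1c(-c2ccc(F)cc2F)sc(N)c1C(=O)c1ccc(Cl)cc1` gives 1%, and compound 3 `COc1ccc(-c2sc(N)c(C(=O)c3ccc(Cl)c(Cl)c3)c2CC(C)(C)C)cc1` gives 1%. Compound 2 thus stands level with compound 1 and compound 3 at the digits shown, and the differences among the three lie within the scatter, so no order can be read from them. Compound 4 `CC(C)(C)Cc1c(-c2cn[nH]c2)sc(N)c1C(=O)c1ccc(Cl)cc1` has not yet been measured. It differs from compound 2 in one place: 1H-pyrazol-4-yl in place of 2,4-difluorophenyl on an aromatic carbon. Among the compounds with values here, no step between measured compounds is available to anchor this change. Since every measured value in this assay is near zero, no step beyond the scatter is expected. Compound 4 is expected to show 3%, with a range from -8% to 15%. The estimated step is a number 2 percentage points higher from compound 2 to compound 4 (within the scatter).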

Compound 4, a percentage reported as inhibition, at one concentration (the size of the read-out at that concentration, not a potency): 1%
Beside the measured number, compound 4's estimate is 2 percentage points above it, and the stated range covers the measured number.
By their numbers in this assay, from the lowest: compounds 1, 2, 3 and 4 (each within the scatter of the next).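

Within the data shown here, the step of no change at the digits printed from compound 2 to compound 4 (within the scatter) comes with 1H-pyrazol-4-yl in place of 2,4-difluorophenyl next to the ring sulfur in this assay and is the first single-place comparison. At this position, a five-membered aromatic ring with 2 hetero atoms, bearing a hydrogen-bond donor and acceptor, reads the same as the six-membered carbon ring. No evidence bears on this result.

Because the read-out stays level, the compounds shown leave open whether any group at this position would raise inhibition, such as a carboxylic acid or an aminomethyl group.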